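The source may hold more compounds than are shown below. What is called first, only, known or untested is meant among the compounds shown, and "the series" means these compounds.

Measured so far:
- compound 1 `O=C(Nc1ccc(Sc2nc3ccccc3s2)cc1)c1cc(Br)cc(Br)c1O` gives 66000 nM
- compound 2 `O=C(Nc1ccc(Sc2nc3ccccc3s2)cc1)c1cc(Br)cc(Br)c1` gives > 100000 nM, which is a limit of the assay and not a number

In an ADME assay on HEK293 cells (Homo sapiens) for cytotoxicity, read by reporter gene assay and resazurin assay, with a stated time of 48 h (on this read-out higher numbers stand for lower toxicity in this test and lower numbers for higher toxicity in this test), compound 1 gives 66000 nM. On these data alone, compound 2 reaches only the limit (the limit of > 100000 nM in this assay, at which 1 of the 2 values shown sits), so its exact value is unknown. Going by the values given here, the one measured step is an at least 1.5-fold higher number from compound 1 to compound 2 (0.18 log units; that floor lies within the scatter), a change that was hydrogen in place of hydroxy on an aromatic carbon.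

Compound 3 `O=C(Nc1ccc(Sc2nc3ccccc3s2)cc1)c1cccc(Br)c1O` has not yet been tested in this assay. Its change from compound 2 is 3-bromo-2-hydroxyphenyl in place of 3,5-dibromophenyl on a carbonyl carbon. This brings a hydroxy back while one bromine is gone, so the step from compound 1 to compound 2 bears on it in the opposite direction, though that step was small and its floor lies within the scatter. The expected step is an at least 1.4-fold lower number from compound 2 to compound 3 (0.15 log units; that floor lies within the scatter), a slight fall or none beyond the scatter. Compound 3 is therefore estimated at 70000 nM, between 30000 nM and 150000 nM.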

Compound 3, half-maximal cytotoxic concentration: 71000 nM
For compound 3 the middle estimate is 1.0-fold (0.01 log units) below the measured one; the range from low to high includes it.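

In this assay, hydrogen in place of bromo on an aromatic carbon gives a 1.1-fold higher number from compound 1 to compound 3 (0.03 log units; within the scatter), so this bromine makes no difference that this test can distinguish. The swap to 3-bromo-2-hydroxyphenyl in place of 3,5-dibromophenyl on a carbonyl carbon gives an at least 1.4-fold lower number from compound 2 to compound 3 (0.14 log units; that floor lies within the scatter), which sets only a floor on the step and does not establish a change beyond the scatter. Compound 2 stands at a limit and not at a number, so the true size of that step stays unknown: the limit of > 100000 nM in this assay, at which 1 of the 3 values shown sits.

The compounds shown leave open how this test would respond to an amine or a carboxylic acid in place of the hydroxy. They also leave open whether a methoxy group or a chlorine on the same ring would give a reading that differs beyond the scatter.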